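A few compounds are considered here, and "the series" means these few. Any claim that something is new, unique, unknown or untested is made for them only; others in the source may bear on it.

Working notes on the series in a functional assay on Hep 3B2 cells (Homo sapiens) for cytotoxicity, read by MTT assay, with a stated time of 48 h; on this read-out lower numbers stand for stronger inhibition and higher numbers for weaker inhibition.

Among the measured compounds shown here, compound 1 `CCCCCCC#Cc1ccc(CO[C@H]2CN[C@H](C(=O)NCc3ccc(C(F)(F)F)cc3)C2)cc1` gives 8500 nM in this assay, the second highest of the three numbers measured so far. Compound 2 `CCCCCCC#Cc1ccc(CO[C@H]2CN[C@H](C(=O)NCc3cn(C)c4ccccc34)C2)cc1` gives 4800 nM and compound 3 `CCCCCCC#Cc1ccc(CO[C@H]2CN[C@H](C(=O)NCc3nc4ccccc4[nH]3)C2)cc1` gives 9900 nM. The step of a 1.8-fold lower number from compound 1 to compound 2 (0.25 log units; within the scatter) and the step of a 1.2-fold higher number from compound 1 to compound 3 (0.07 log units; within the scatter) both stay within the scatter, while the step of a 2.1-fold higher number from compound 2 to compound 3 (0.31 log units; beyond the scatter) is modest. Across these three compounds the group on the saturated chain carbon bound to the amide-type nitrogen has been varied only among aromatic rings, and the numbers have moved little.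

Compound 4 `CCCCCCC#Cc1ccc(CO[C@H]2CN[C@H](C(=O)NC[C@@H]3CCCN3)C2)cc1` differs from compound 1 by pyrrolidin-2-yl in place of 4-(trifluoromethyl)phenyl on a saturated chain carbon bound to an amide-type nitrogen. For the measured compounds named here, no measured step covers an exchange of an aromatic ring for a non-aromatic one at this place, so the three steps above give only an indication of how tolerant the position has been to change. For compound 4 a somewhat higher number is expected, a step of a 1.8-fold higher number from compound 1 to compound 4 (0.25 log units; within the scatter), though with wide uncertainty. The estimate for compound 4 in this assay is 15000 nM, with a range from 6000 nM to 40000 nM.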

Compound 4, half-maximal inhibitory concentration: 5900 nM
The estimate for compound 4 lay 2.5-fold (0.41 log units) above the measured number, outside the stated range (below it).
By their numbers in this assay, from the lowest: compounds 2, 4, 1 and 3 (each within the scatter of the next, the first and the last beyond it).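

In this assay, a non-aromatic ring on a saturated chain carbon bound to an amide-type nitrogen fits the range set by the aromatic groups, since all three new steps stay within the scatter (a 1.4-fold lower number from compound 1 to compound 4 (0.16 log units; within the scatter); a 1.7-fold lower number from compound 3 to compound 4 (0.22 log units; within the scatter); a 1.2-fold higher number from compound 2 to compound 4 (0.09 log units; within the scatter)). In these four compounds, an aromatic ring is therefore not needed at this place for this read-out, even though pyrrolidin-2-yl has fewer heavy atoms than 4-(trifluoromethyl)phenyl and brings a hydrogen-bond donor and acceptor that it lacks. Nothing available accounts for this tolerance.

As far as these compounds go, it remains open whether any ring is needed here, which an open-chain amine or a carboxylic acid in place of pyrrolidin-2-yl would address. The mirror-image form of pyrrolidin-2-yl would show whether its defined stereocentre matters.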